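A few compounds are considered here, and "the series" means these few. Any claim that something is new, unique, unknown or untested is made for them only; others in the source may bear on it.

Measured in a functional assay on Jurkat cells (Homo sapiens) for inhibition, read by CCK-8 assay, with a stated time of 48 h; on this read-out higher numbers stand for weaker inhibition of growth and lower numbers for stronger inhibition of growth:
- Compound 1 `Cc1ccccc1Nc1nc(NC2CC2)ncc1Cl` gives > 100000 nM, which is a limit.
- Compound 2 `Cc1ccc(Nc2ncc(Cl)c(Nc3ccccc3C)n2)cc1` gives > 100000 nM, which is also a limit.
- Compound 3 `Cc1ccccc1Nc1nc(Nc2ccccn2)ncc1Cl` gives 20100 nM.

Compound 1 has no exact number and stands at the limit of > 100000 nM in this assay, at which 2 of the 3 values shown sit. The step to be judged leads to compound 4 `Cc1ccccc1Nc1nc(NCc2ccncc2)ncc1Cl`, and the structural change is (pyridin-4-yl)methyl in place of cyclopropyl on a nitrogen on an aromatic ring. Going by the values given here, three measured steps bear on it. Among the compounds with values here, the first is a step that the two limits leave unreadable from compound 1 to compound 2, which gives no size to work with. The other two are an at least 4.9-fold lower number from compound 1 to compound 3 (0.69 log units; beyond the scatter) and an at least 4.9-fold lower number from compound 2 to compound 3 (0.69 log units; beyond the scatter). Within the data shown here, both end at compound 3, the only compound of the three with a true number, and its pyridin-2-yl group is the nearest match to the entering (pyridin-4-yl)methyl. Compound 4 is not the same, however, and its pyridine ring is attached in a different way. With only compound 3 as a guide, a lower number than the limit of compound 1 is expected, meaning stronger inhibition of growth, but only a modest gain and with real uncertainty. Compound 4 might also reach the limit and give no number at all. The expected change is an at least 2.5-fold lower number from compound 1 to compound 4 (0.39 log units; beyond the scatter). For compound 4 the estimated value is 40000 nM, with an expected range from 13000 nM to 100000 nM.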

Compound 4, concentration for 50% growth inhibition: > 100000 nM
Compound 4: no number, only a limit (the forecaster's own chance of this, stated with the estimate: 35%); middle value at least 2.5-fold (0.39 log units) from the limit.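

In this assay, putting (pyridin-4-yl)methyl in place of pyridin-2-yl on this nitrogen gives an at least 4.9-fold higher number from compound 3 to compound 4 (0.69 log units; beyond the scatter), so having a pyridine ring in this place does not by itself go with stronger inhibition of growth. The steps from compound 1 and from compound 2 to compound 4 cannot be read, as both ends of each step are limits. Compound 3 therefore remains the only compound here with a true number, and what is known about this position rests on that single compound: the limit of > 100000 nM in this assay, at which 3 of the 4 values shown sit.

Compound 3 and compound 4 differ both in how the pyridine ring is attached and in which pyridine it is, and the compounds shown do not pull these two changes apart; a pyridin-4-yl group set directly on this nitrogen, or a (pyridin-2-yl)methyl group, would do so. On these data alone, it also remains open whether the pyridin-2-yl result extends to other rings with nitrogen in them, such as pyrimidin-2-yl, or to a plain phenyl group.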